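The source may hold more compounds than are shown below. What is called first, only, known or untested is meant among the compounds shown, and "the series" means these compounds.

Measured so far:
- compound 1, `FCCCOc1ccc2[nH]ccc2c1`: 2.5
- compound 2, `CC[C@H](F)[C@H](C)O`: 0.68
- compound 3, `CC(=O)N1CCC[C@H]1C(=O)OCCF`: -0.43

In a physicochemical assay for lipophilicity, read by NMR (a lower number here means a more polar compound, a higher number a more lipophilic compound), compound 1 gives 2.5, the highest of the three numbers. The nearest of the others is compound 2, which gives 0.68; the gap to compound 1 lies beyond the scatter. Furthest is compound 3, which gives -0.43, a gap to compound 1 that is also beyond the scatter. For the measured compounds named here, the three compounds share no common core, so no single-point step between measured compounds is available, and nothing measured so far isolates the effect of a fluoro on a saturated chain.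

The next compound, compound 4, `CCCOc1ccc2[nH]ccc2c1`, is to be measured in this assay. It differs from compound 1 in one place:

hydrogen in place of fluoro on a saturated chain carbon, three bonds along the chain from an oxygen on an aromatic ring

Going by the values given here, with no measured step of this kind to lean on, the expectation is a small step, a number 0.20 log units higher from compound 1 to compound 4 (within the scatter), a slight move toward the lipophilic end that would not be distinguishable from repeat scatter. Compound 4 is therefore expected to give about 2.7, with a range from 2.3 to 3.1.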

Compound 4, partition coefficient: 2.9
Beside the measured number, compound 4's estimate is 0.20 log units below it, within the range that was stated.
By their numbers in this assay, from the lowest: compound 3; then compound 2; then compound 1; then compound 4.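

In this assay, for the compounds shown here, the pair gives the first single-place step: a number 0.40 log units higher from compound 1 to compound 4 (beyond the scatter) for hydrogen in place of fluoro on a saturated chain carbon, three bonds along the chain from an oxygen on an aromatic ring. The earlier compounds shown here share no common core and could not isolate this change, whereas 3-fluoropropyl to propyl now has a measured size on the core of compound 1, a modest step that places compound 4 above compound 1 on this scale. No measurement in hand bears on why the step has this size.

Still open, on these data alone, is whether a step of similar size appears for 2-fluoroethyl to ethyl or fluoromethyl to methyl, or for the same change on another core, since one pair cannot establish a pattern and compound 2 and compound 3 offer no single-place comparison. Also open, as far as these compounds go, is how a hydroxyl group, an amine or a longer chain in place of the fluoro on this saturated chain carbon would stand against compound 1 and compound 4 in this assay on the same core.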